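Removing a Methyl from the Oxygen: What to Expect

This account rests on a few compounds, and the source may have more. Where it says the series, first, only, none or still open, it means among the compounds named here.

Of the compounds shown here, two sharing one core have been tested in a functional assay on SN12C cells (Homo sapiens) for cytotoxicity, read by sulforhodamine B assay, with a stated time of 48 h, tested at 0.001 uM; on this read-out lower numbers stand for a stronger effect and higher numbers for a weaker effect at the one concentration tested. Compound 1 `Cc1cc(O)cc(-c2nn(CC#N)cc2-c2ccnc(-c3ccc(Oc4ccccc4)cc3)c2)c1` gives 94% in this assay, and compound 2 `COc1cc(C)cc(-c2nn(CC#N)cc2-c2ccnc(-c3ccc(N(C)C)cc3)c2)c1` gives 100%. On these two numbers compound 2 sits alongside compound 1, the two values within the usual scatter of each other, so neither can be called the stronger.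

Compound 3 `Cc1cc(O)cc(-c2nn(CC#N)cc2-c2ccnc(-c3ccc(N(C)C)cc3)c2)c1` is reached from compound 2 by a single change: hydrogen in place of methyl on an oxygen on an aromatic ring. Within the data shown here, no pair among the measured compounds differs by exactly this change, so its effect in this assay has not been seen directly.

Both measured values sit near the top of the range, and the change is small. The step from compound 2 to compound 3 is therefore expected to be a number 3 percentage points lower from compound 2 to compound 3 (within the scatter), that is, no change beyond the scatter. Compound 3 is estimated at 97%, within the range 85% to 105%.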

Compound 3, a percentage reported as activity, at one concentration (the size of the read-out at that concentration, not a potency): 97%
Compound 3: the middle estimate sits on the measured number at the digits printed; low and high end bracket the measured number.
By their numbers in this assay, from the lowest: compounds 1, 3 and 2 (each within the scatter of the next).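

Among these compounds, compound 3 gives the first direct reading of methoxy to hydroxy on this ring. In this assay the step is a number 3 percentage points lower from compound 2 to compound 3 (within the scatter) and so, with dimethylamino held in place, this change leaves no readable mark at this one concentration. Compound 3 also connects the two earlier compounds, which differ in more than one place: with the hydroxy held in place, dimethylamino in place of phenoxy gives a number 3 percentage points higher from compound 1 to compound 3 (within the scatter) and likewise stays within the scatter. No measurement at hand offers a reason for either result.

As far as these compounds go, whether either change would matter at higher concentrations stays open, as all three compounds are compared at a single low concentration. The compounds shown also leave open how a longer chain such as ethyl on this oxygen, or a carboxylic acid in place of the hydroxy, would read.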